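Cytotoxicity of pyrrolidinone sulfonamides on kidney cells

This account rests on a few compounds, and the source may have more. Where it says the series, first, only, none or still open, it means among the compounds named here.

Compound 1 `COc1ccc([C@H]2CC(=O)N(c3cccc(C(F)(F)F)c3)C2)cc1OC1CCCC1` — in a functional assay on HEK293 cells (Homo sapiens) for cytotoxicity (on this read-out lower numbers stand for higher toxicity in this test and higher numbers for lower toxicity in this test), compound 1 gives > 10000 nM, a limit of the test.
Compound 2 `COc1ccc([C@H]2CC(=O)N(c3cccc(NS(=O)(=O)c4ccccc4Cl)c3)C2)cc1OC1CCCC1` — in this assay compound 2 gives > 10000 nM, likewise a limit.

Compound 2 stands at the limit of > 10000 nM in this assay, at which 2 of the 2 values shown sit. Within the data shown here, the only measured step, a step that the two limits leave unreadable from compound 1 to compound 2, gives no size, since both ends are limits. Compound 3 `COc1ccc([C@H]2CC(=O)N(c3cccc(NS(=O)(=O)c4cc(Br)c(Cl)s4)c3)C2)cc1OC1CCCC1` carries the change (4-bromo-5-chlorothiophen-2-yl in place of 2-chlorophenyl on a sulfonyl sulfur). Among the measured compounds shown here, no measured step bears on this exchange. The step that the limit leaves unreadable from compound 2 to compound 3 is therefore expected to stay within the scatter, with compound 3 most likely reported again as a limit. Compound 3 is expected at 20000 nM, ranging from 8000 nM to 60000 nM.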

Compound 3, half-maximal cytotoxic concentration: > 10000 nM
Compound 3: no number, only a limit; the forecaster's own chance of this, stated with the estimate: 80%; the middle value is on the limit's open side.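

The steps among compound 1, compound 2 and compound 3 cannot be read, since all three stand at one limit: the limit of > 10000 nM in this assay, at which 3 of the 3 values shown sit.

As far as these compounds go, how far these three compounds differ in this assay stays open, as does the size of either exchange.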